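Replacing the amide group of compound 2

The compounds below may be only part of what the source reports. "The series", "measured", "known", "first", "only" and "open" are said of these compounds alone.

In an ADME assay on the whole organism (Rattus norvegicus, strain Wistar Han) for pharmacokinetics, read by LC-MS, with a stated time of 7 h, at a dose of 3 mg/kg by the oral route (a lower number here means that a smaller share of the oral dose reaches the circulation, a higher number that a larger share of the oral dose reaches the circulation), compound 2 `CNC(=O)c1cc(C(=O)N[C@H]2[C@@H]3COC[C@@H]32)c([C@@H](C)c2ccccc2)o1` gives 100%, the highest of the three numbers measured, ahead of compound 3 `CNC(=O)c1cc(C(=O)N[C@H]2CC[C@H](OC)CC2)n([C@@H](C)c2ccccc2)n1` at 80% and compound 1 `CNC(=O)c1cc(C(=O)N[C@H]2CC[C@H](O)CC2)n([C@@H](C)c2ccccc2)n1` at 58%. Compound 4 `CNC(=O)c1cc(C(=O)N[C@H]2CC[C@H](O)CC2)c([C@@H](C)c2ccccc2)o1` differs from compound 2 in one place: a group of 7 heavy atoms (6 carbon, 1 oxygen; one six-membered non-aromatic ring of carbon only) in place of a group of 6 heavy atoms (5 carbon, 1 oxygen; one three-membered non-aromatic ring of carbon only, one five-membered non-aromatic ring with 1 hetero atom), on an amide-type nitrogen. Among the measured compounds shown here, no measured step covers this change directly. For the measured compounds named here, the only measured step is a number 22 percentage points higher from compound 1 to compound 3 (beyond the scatter), on a different core, where methyl takes the place of the hydroxyl hydrogen. Compound 4 carries the same 4-hydroxycyclohexyl as compound 1, and compound 1 stands at 58%, on the lower side of that step. A fall beyond the scatter is therefore expected, an estimated a number 40 percentage points lower from compound 2 to compound 4 (beyond the scatter) in this assay. For compound 4 the expected value is 60%, with an estimated range of 35% to 85%.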

Compound 4, oral bioavailability: 72%
The estimate for compound 4 lay 12 percentage points below the measured number; the range from low to high includes it.
By their numbers in this assay, from the lowest: compound 1; then compounds 4 and 3 (each within the scatter of the next); then compound 2.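

In this assay, 4-hydroxycyclohexyl on the amide-type nitrogen gives a number 28 percentage points lower from compound 2 to compound 4 (beyond the scatter), a modest change. Among the compounds shown here, the group on this nitrogen alone thus moves the number beyond the scatter on a fixed core, which the earlier compounds could not show, as their only step lay at the hydroxyl oxygen. Nothing shown accounts for this step.

From the compounds shown here alone, whether methyl on that hydroxyl oxygen would repeat, on the core of compound 4, the gain seen in a number 22 percentage points higher from compound 1 to compound 3 (beyond the scatter) stays open. So does the effect of an amine, such as 4-aminocyclohexyl, on this nitrogen.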